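Amide substituents on a cytotoxic pyrazolopyridine: compound 4

The source may report more compounds than this note shows. Statements on the series, on what has been measured and on what is new or still open speak of the compounds shown alone.

Measured so far:
- compound 1 `CCNC(=O)Cn1nc(N)c2c(C(F)(F)F)cc(-c3ccccc3)nc21`: 18800 nM
- compound 2 `CCCNC(=O)Cn1nc(N)c2c(C(F)(F)F)cc(-c3ccccc3)nc21`: 16500 nM
- compound 3 `Nc1nn(CC(=O)NCc2ccco2)c2nc(-c3ccccc3)cc(C(F)(F)F)c12`: 7700 nM

All three compounds share one core and differ only in the group attached to the amide nitrogen. In a functional assay on A549 cells (Homo sapiens) for cytotoxicity, read by MTT assay, with a stated time of 24 h (a higher number here means a weaker inhibitor, a lower number a stronger inhibitor), compound 2 gives 16500 nM, the second highest of the three numbers; compound 1 sits within the scatter of it, with a 1.1-fold lower number from compound 1 to compound 2 (0.06 log units; within the scatter), while compound 3 is further away, with a 2.1-fold lower number from compound 2 to compound 3 (0.33 log units; beyond the scatter).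

The unmeasured compound 4 `Nc1nn(CC(=O)N2CCOCC2)c2nc(-c3ccccc3)cc(C(F)(F)F)c12` changes the amide end once more: morpholin-4-yl in place of propylamino on a carbonyl carbon. Among the compounds with values here, none of the measured steps makes exactly this change. The nearest comparisons are the growth of the chain, a 1.1-fold lower number from compound 1 to compound 2 (0.06 log units; within the scatter), which did nothing beyond the scatter, and the swap to a furan, a 2.4-fold lower number from compound 1 to compound 3 (0.39 log units; beyond the scatter) and a 2.1-fold lower number from compound 2 to compound 3 (0.33 log units; beyond the scatter), which gave modest improvements. On that basis the step of a 1.2-fold lower number from compound 2 to compound 4 (0.07 log units; within the scatter) is expected to be small, probably not beyond the scatter, with a slight lean toward a lower number. Compound 4 is therefore estimated at 14000 nM in this assay, with a plausible range from 6000 nM to 35000 nM.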

Compound 4, half-maximal inhibitory concentration: 5400 nM
The estimate for compound 4 lay 2.6-fold (0.41 log units) above the measured number; the whole stated range lies above it.
By their numbers in this assay, from the lowest: compounds 4 and 3 (each within the scatter of the next); then compounds 2 and 1 (each within the scatter of the next).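

Putting morpholin-4-yl in place of the open chains on the carbonyl carbon lowers the number in this assay, with a 3.1-fold lower number from compound 2 to compound 4 (0.49 log units; beyond the scatter) and a 3.5-fold lower number from compound 1 to compound 4 (0.54 log units; beyond the scatter). So this position accepts a six-membered ring that leaves the amide without its hydrogen, and the cytotoxicity does not suffer. The earlier lower number came from the furan-2-yl group in compound 3, which keeps that hydrogen, yet the two ring-bearing ends lie within the scatter of each other, with a 1.4-fold lower number from compound 3 to compound 4 (0.15 log units; within the scatter).

Nothing measured here speaks to the cause of these shifts. Going by these compounds, it remains open whether the ring, the ring oxygen or the lost amide hydrogen matters most, and a piperidin-1-yl group, which has no ring oxygen, or an N-methylpropylamino group, which has no ring, could help separate them.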